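This account rests on a few compounds, and the source may have more. Where it says the series, first, only, none or still open, it means among the compounds named here.

Measured so far:
- compound 1, `CN1CCN(CCCCCn2c3c(c4ccccc42)C(=O)c2c[n+]([O-])c4ccccc4c2C3=O)CC1`: 1640 nM
- compound 2, `O=C1c2c[n+]([O-])c3ccccc3c2C(=O)c2c1c1ccccc1n2Cc1cn([C@H]2C[C@H](O)[C@@H](CO)O2)nn1`: 280 nM

Both compounds were read in a toxicity assay on L02 cells (Homo sapiens) for cytotoxicity, read by MTT assay, with a stated time of 72 h; on this read-out lower numbers stand for stronger inhibition and higher numbers for weaker inhibition. Compound 2 stands lowest of the two numbers; its nearest neighbour is compound 1, whose value lies beyond the usual scatter of repeated measurements, so compound 2 is the stronger of the two on this read-out.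

The next compound in the series is compound 3, `CC1(C)OCC(Cn2cc(Cn3c4c(c5ccccc53)C(=O)c3c[n+]([O-])c5ccccc5c3C4=O)nn2)O1`. It differs from compound 2 in one place: (2,2-dimethyl-1,3-dioxolan-4-yl)methyl in place of 4-hydroxy-5-(hydroxymethyl)oxolan-2-yl on an aromatic nitrogen. Within the data shown here, no step between two measured compounds bears on such a change, so there is nothing to anchor its size. Both hydrogen-bond donors of the leaving group go, and a group of the same heavy-atom count with no donors comes in. Going from compound 2, a modest move towards a higher number is expected for compound 3, of the order a 2.1-fold higher number from compound 2 to compound 3 (0.33 log units; beyond the scatter), though a result within the scatter of compound 2 would not surprise.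

For compound 3 in this assay the estimate is 600 nM, with a range from 200 nM to 1800 nM.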

Compound 3, half-maximal inhibitory concentration: 120 nM
For compound 3 the middle estimate is 5.0-fold (0.70 log units) above the measured one; measured number outside the range, below it.
By their numbers in this assay, from the lowest: compound 3; then compound 2; then compound 1.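

Moving from 4-hydroxy-5-(hydroxymethyl)oxolan-2-yl to (2,2-dimethyl-1,3-dioxolan-4-yl)methyl on an aromatic nitrogen of the five-membered aromatic ring with 3 nitrogen gives a 2.3-fold lower number from compound 2 to compound 3 (0.37 log units; beyond the scatter) in this assay, so on this read-out the group with 0 hydrogen-bond donors gives stronger inhibition than the group with 2. This pair also shows that the 3 defined stereocentres of the leaving group are not needed for a number at this level, since the entering group has none defined. Nothing measured accounts for the step.

The donors, acceptors, ring and stereocentres all change together in this one pair, so their shares in the step stay unseparated. Going by these compounds, whether a 2-hydroxyethyl chain, a carboxylic acid or a primary amine at this nitrogen would follow compound 3 or compound 2 remains open.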